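The source may hold more compounds than are shown below. What is called first, only, known or untested is meant among the compounds shown, and "the series" means these compounds.

Measured so far:
- compound 2, `FC(F)(F)c1ccccc1Cn1nnc2c(NC3CCCC3)nc(-c3ccccc3)nc21`, 0.6 nM
- compound 1, `CCCNc1nc(-c2ccccc2)nc2c1nnn2Cc1ccccc1C(F)(F)F`, "not determined" (no result reported)

Among the compounds with values here, compound 2 is the only compound with a number in an assay on Cerebral cortex for displacement of a labelled ligand from adenosine receptor A1 (Bos taurus); on this read-out lower numbers stand for stronger inhibition and higher numbers for weaker inhibition; compound 1 shares its core but carries a propylamino group in place of the cyclopentylamino group and has no reported result, so compound 2 stands alone and nothing can be said about its rank.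

Compound 3, `FC(F)(F)c1ccccc1Cn1nnc2c(NC3CCCCC3)nc(-c3ccccc3)nc21`, is not yet measured. It differs from compound 2 in one place: cyclohexyl in place of cyclopentyl on a nitrogen on an aromatic ring. Within the data shown here, no step between two measured compounds is known here that would show what this kind of change does, so the expectation rests on the size of the change alone. Because compound 2 reaches 0.6 nM, compound 3 is expected to stay strong, with a step of a 2.5-fold higher number from compound 2 to compound 3 (0.40 log units; beyond the scatter) that is expected to be small and, if anything, toward weaker inhibition. The estimate for compound 3 in this assay is 1.5 nM, with a range from 0.5 nM to 5 nM.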

Compound 3, inhibition constant: 6.8 nM
Compound 3: the middle estimate sits 4.5-fold (0.66 log units) below what was measured; the measured number lies above the stated range.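

Going from a five-membered to a six-membered non-aromatic ring on a nitrogen on an aromatic ring looks like a small edit, yet in this assay cyclohexyl in place of cyclopentyl gives an 11-fold higher number from compound 2 to compound 3 (1.05 log units; beyond the scatter), so this place clearly responds to ring size. The change does not abolish binding, since compound 3 still gives 6.8 nM, which is a strong result on this read-out. Nothing available here explains why the larger ring gives the weaker inhibition.

Steps involving compound 1 cannot be read, so it remains open how the propylamino group, an open chain, compares with either ring. Also open, on these data alone, is how a smaller cyclobutyl ring or a larger cycloheptyl ring on the same nitrogen would fare, and so whether cyclopentyl is the best ring size here.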